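Chloro step carried from one core to another

This account rests on a few compounds, and the source may have more. Where it says the series, first, only, none or still open, it means among the compounds named here.

Measured compounds in a functional assay on the whole organism for inhibition, with Rattus norvegicus as the target, read by ELISA, with stated times of 30 min and 6 h, at a dose of 30 mg/kg by the oral route; a higher number here means more inhibition at the dose given (going by the name of the read-out), a lower number less inhibition:
compound 1 `N=c1sc(=S)[nH]c2c1cc(-c1ccccc1)n2-c1ccccc1` gives 0%
compound 2 `N=c1sc(=S)[nH]c2c1cc(-c1ccc(Cl)cc1)n2-c1ccccc1` gives 2%
compound 3 `CCC(C)Sc1nc2c(cc(-c3ccccc3)n2-c2ccccc2)c(=N)s1` gives 50%

Compound 1 and compound 2 share a core and differ by chloro in place of hydrogen on an aromatic carbon; the step of a number 2 percentage points higher from compound 1 to compound 2 (within the scatter) is within the usual scatter, so the two values are read as the same. Compound 3 carries a different core; how it differs from compound 1 is not broken down here. In this assay compound 3 stands highest of the three numbers, beyond the scatter from both compound 1 and compound 2.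

Compound 4 `CCC(C)Sc1nc2c(cc(-c3ccc(Cl)cc3)n2-c2ccccc2)c(=N)s1` is not yet measured. It differs from compound 3 by chloro in place of hydrogen on an aromatic carbon, and the place of the change is the same as between compound 1 and compound 2, so this is the same change. Among the measured compounds shown here, the only information on what this change does comes from one pair on the other core, where it moved the value by a number 2 percentage points higher from compound 1 to compound 2 (within the scatter), and nothing shows whether the core of compound 3 answers the change differently.

For compound 4 in this assay the expected step from compound 3 is no change at the digits printed from compound 3 to compound 4 (within the scatter), estimated to be small because the earlier step of a number 2 percentage points higher from compound 1 to compound 2 (within the scatter) was within the scatter. Compound 4 is therefore expected to give about 50%, with a likely range from 30% to 70%.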

Compound 4, a percentage reported as inhibition, in the whole organism at one dose (the size of the read-out at that dose, not a potency): 2%
The estimate for compound 4 lay 48 percentage points above the measured number; the measured number lies below the stated range.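

In this assay, phenyl to 4-chlorophenyl gives a number 48 percentage points lower from compound 3 to compound 4 (beyond the scatter), so in this series the result of the change on the core of compound 1 does not carry over to the core of compound 3, and the two steps differ: the same change on two cores in this assay, a number 2 percentage points higher (within the scatter) from compound 1 to compound 2 and a number 48 percentage points lower (beyond the scatter) from compound 3 to compound 4, 50 percentage points apart, beyond the scatter of two such steps

Compound 1 gives 0%, which leaves almost no room for a lower number on that core, so that pair could not have shown a fall of the size seen on the core of compound 3. The four compounds do not show why the two steps part, and with one pair on each core and one dose in the whole organism, they give neither a potency nor a general rule for chloro on either core.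

From the compounds shown here alone, it remains open whether the fall belongs to chloro alone or also follows other groups at the same place, such as fluoro, methoxy or a carboxylic acid. Also open, going by these compounds, is whether 4-chlorophenyl would give the same fall with a longer chain or an amine in place of the chain of compound 3.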